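Swapping the Hydroxamate Region in an Azetidine Amide Series

The compounds below may be only part of what the source reports. "The series", "measured", "known", "first", "only" and "open" are said of these compounds alone.

Compound 1 `O=C(NO)c1ccc(N(Cc2ccc(C3CCOCC3)cc2)C(=O)[C@H]2CCN2S(=O)(=O)c2c(F)c(F)c(F)c(F)c2F)cc1` and compound 2 `CONC(=O)c1ccc(N(Cc2ccc(C3CCCCC3)cn2)C(=O)[C@H]2CCN2S(=O)(=O)c2c(F)c(F)c(F)c(F)c2F)cc1O` share a core built around a small saturated ring that carries a sulfonyl group, and they differ in the groups hung on the amide-type nitrogen. The measurement that matters here is a functional assay on MCF7 cells (Homo sapiens) for antiproliferative activity, with a stated time of 72 h; a higher number here means that more compound is needed for the effect, a lower number that less compound is needed. In this assay compound 1 returns only a limit, > 10000 nM. For compound 2 this assay reports "not determined" (no result reported), so no number places it on the scale. Going by the values given here, the one value present in this set is the limit of > 10000 nM in this assay, at which 1 of the 2 values shown sits, and it belongs to compound 1.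

Compound 3 `O=C([C@H]1CCN1S(=O)(=O)c1c(F)c(F)c(F)c(F)c1F)N(Cc1ccc(C2CCCCC2)cn1)c1ccc2c(=O)[nH]ccc2c1` keeps the core of compound 2 and changes one part: a group of 11 heavy atoms (9 carbon, 1 nitrogen, 1 oxygen; one six-membered aromatic ring of carbon only, one six-membered aromatic ring with 1 hetero atom) in place of a group of 12 heavy atoms (8 carbon, 1 nitrogen, 3 oxygen; one six-membered aromatic ring of carbon only), on an amide-type nitrogen. Among the compounds with values here, no pair of measured compounds here differs in a single place, so no measured step can guide the size or the direction of this change. With compound 1 reaching only its limit and compound 2 unmeasured, the expectation for compound 3 rests on little. Compound 3 is expected to give about 6000 nM in this assay, within a range from 1000 nM to 30000 nM, and a result that is again only a limit is quite possible.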

Compound 3, half-maximal effective concentration: 2200 nM
Compound 3: middle estimate off by 2.7-fold (0.44 log units), on the high side; the range from low to high includes it.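

In this assay compound 3 gives 2200 nM, but no step can be read from this result: compound 2 has no number to compare, and compound 1 differs from compound 3 in more than one place. Still open, from the compounds shown here alone, is whether replacing the 3-hydroxy-4-(methoxycarbamoyl)phenyl group alone changes the antiproliferative effect, and by how much.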